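Amino to Hydrogen on a Chloro-Bearing Fused Core

A few compounds are considered here, and "the series" means these few. Any claim that something is new, unique, unknown or untested is made for them only; others in the source may bear on it.

The study reports three compounds carrying a chloromethyl-substituted benzyl group on a fused two-ring system, together with one that has not yet been tested. In a functional assay on RXF 393 cells (Homo sapiens) for cytotoxicity, read by sulforhodamine B assay, with a stated time of 48 h (on this read-out higher numbers stand for weaker inhibition of growth and lower numbers for stronger inhibition of growth), compound 1 `ClCc1cccc(Cn2cnc3c(Cl)nc(Cl)nc32)c1` gives 2090 nM, and compound 2 `ClCc1cccc(Cn2cnc3nc(Cl)nc(Cl)c32)c1` gives 2630 nM; these two values show no difference between them that goes beyond the scatter. Among the measured compounds shown here, compound 3 `Nc1nc(Cl)c2ncn(Cc3cccc(CCl)c3)c2n1`, which carries an amino group as well as a chloro group on its fused core, is reported in this assay only as "not determined" (no result reported), so compound 3 stands without a number and offers no anchor for the step that follows.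

Compound 4 `ClCc1cccc(Cn2cnc3c(Cl)ncnc32)c1` differs from compound 3 in a single change: hydrogen in place of amino on an aromatic carbon. For the measured compounds named here, no measured pair brackets this exact change. Going by the values given here, the expected size of the step in this assay therefore cannot be taken from a precedent, and no direction can be set for it with confidence; the only guide is that compounds 1 and 2, which also lack an amino group, sit in the same general region as each other. On that footing, compound 4 is expected to fall near 3000 nM, with a range from 800 nM to 12000 nM.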

Compound 4, concentration for total growth inhibition: 24000 nM
Estimate against measurement, compound 4: 8.0-fold (0.90 log units) below; the measured number lies above the stated range.
By their numbers in this assay, from the lowest: compounds 1 and 2 (each within the scatter of the next); then compound 4.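

The position between two ring nitrogen atoms now has a measured consequence: with hydrogen in place of chloro on this aromatic carbon, this assay records an 11-fold higher number from compound 1 to compound 4 (1.06 log units; beyond the scatter), a step beyond the scatter and towards weaker inhibition of growth. Compound 1 and compound 2 could not show this on their own, since both carry a chloro group on that carbon and the group there did not vary between them. The chloro group at this position thus goes with the lower number in this one pair, while the step from compound 3 to compound 4 cannot be read, as compound 3 has no number to start from.

Nothing measured here explains why removing this chloro group has a step of this size. As far as these compounds go, whether a methyl group, a methoxy group or an amine on this carbon would give a number closer to that of compound 1 or closer to that of compound 4 remains open, as does whether the same change would have a similar effect on the core of compound 2.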